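Furan-3-yl in place of 4-chlorophenyl: cytotoxicity expectation

This account rests on a few compounds, and the source may have more. Where it says the series, first, only, none or still open, it means among the compounds named here.

Compound 1 `O=C(c1ccc2c(c1)OCCO2)C1CCN(Cc2coc(-c3ccc(Cl)cc3)n2)CC1` is one of three analogues of a shared core tested in an ADME assay on HEK293 cells (Homo sapiens) for cytotoxicity, read by MTT assay, with a stated time of 36 h; a higher number here means a weaker inhibitor, a lower number a stronger inhibitor. In this assay compound 1 gives > 150 ug/mL, which is a limit of the assay and not a number. Compound 2 `O=C(c1ccc2c(c1)OCCO2)C1CCN(Cc2coc(-c3cccc(F)c3)n2)CC1` likewise gives > 150 ug/mL, a limit. Compound 3 `O=C(c1ccc2c(c1)OCCO2)C1CCN(Cc2coc(-c3ccco3)n2)CC1` gives > 150 ug/mL, again a limit. Because all three values sit at the limit of > 150 ug/mL in this assay, at which 3 of the 3 values shown sit, the steps a step that the two limits leave unreadable from compound 1 to compound 2, a step that the two limits leave unreadable from compound 1 to compound 3 and a step that the two limits leave unreadable from compound 2 to compound 3 cannot be read in size. Compound 4 `O=C(c1ccc2c(c1)OCCO2)C1CCN(Cc2coc(-c3ccoc3)n2)CC1` has not yet been measured; it differs from compound 1 as follows: furan-3-yl in place of 4-chlorophenyl on an aromatic carbon. The measured steps that bear on this change are those from compound 1 to compound 2 and to compound 3, and neither gives a readable size; the step to compound 3 is the closest in kind to the change here. No step beyond the scatter in this assay is therefore expected in either direction. Compound 4 is estimated to give 200 ug/mL, between 150 ug/mL and 400 ug/mL, most likely again reported only as a limit. The step that the limit leaves unreadable from compound 1 to compound 4 is thus expected to be small.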

Compound 4, half-maximal inhibitory concentration: > 150 ug/mL
Compound 4: only a limit was reported; the forecaster's own chance of this, stated with the estimate: 90%; the middle value is on the limit's open side.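

In this assay the reported result for compound 4 is > 150 ug/mL and is a limit, not a number. The steps linking compound 4 to compounds 1, 2 and 3 cannot be read in size because every value is the same limit: the limit of > 150 ug/mL in this assay, at which 4 of the 4 values shown sit. The compounds shown leave open whether these four differ at all in cytotoxicity.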